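The source may report more compounds than this note shows. Statements on the series, on what has been measured and on what is new or still open speak of the compounds shown alone.

Measured so far in an ADME assay on HeLa cells (Homo sapiens) for cytotoxicity, read by MTT assay, with a stated time of 72 h; on this read-out lower numbers stand for higher toxicity in this test and higher numbers for lower toxicity in this test:
- compound 1 `Nc1sc2c(c1-c1nc3ccccc3s1)CCCC2`: 475 ug/mL
- compound 2 `O=[N+]([O-])c1ccccc1/C=N/c1sc2c(c1-c1nc3ccccc3s1)CCCC2`: 369 ug/mL

In this assay, among the compounds with values here, compound 2 gives 369 ug/mL, and this value lies within the usual scatter of the one other number available, 475 ug/mL for compound 1. The series therefore shows no separation so far, and both compounds sit in a high range of concentrations.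

The next compound, compound 3 `Oc1ccccc1/C=N/c1sc2c(c1-c1nc3ccccc3s1)CCCC2`, is reached from compound 2 by a single change: hydroxy in place of nitro on an aromatic carbon. In words, hydroxy stands in place of nitro on an aromatic carbon, ortho to a large group, so that 2-nitrophenyl becomes 2-hydroxyphenyl.

Within the data shown here, no measured pair differs in one place, so the data offer no direct guide to the size of this step. Among the measured compounds shown here, the only hint is that compound 1 at 475 ug/mL and compound 2 at 369 ug/mL do not stand apart beyond the scatter. On that basis, no step beyond the scatter is expected in this assay, and the estimated change is a 1.1-fold higher number from compound 2 to compound 3 (0.04 log units; within the scatter). Compound 3 is expected at 400 ug/mL, with an estimated range of 200 ug/mL to 750 ug/mL.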

Compound 3, half-maximal cytotoxic concentration: 122 ug/mL
Estimate against measurement, compound 3: 3.3-fold (0.52 log units) above; the whole stated range lies above it.
By their numbers in this assay, from the lowest: compound 3; then compounds 2 and 1 (each within the scatter of the next).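

In this assay, the change from 2-nitrophenyl to 2-hydroxyphenyl gives a 3.0-fold lower number from compound 2 to compound 3 (0.48 log units; beyond the scatter), which shows that this place on the aromatic ring, ortho to a large group, can shift the read-out beyond the scatter, and in the direction of higher toxicity in this test. Within the data shown here, the series also separates for the first time: the group of 9 heavy atoms that compound 3 carries in place of one nitrogen atom gives a 3.9-fold lower number from compound 1 to compound 3 (0.59 log units; beyond the scatter), whereas compound 1 and compound 2, the latter with the nitro group, stayed within the scatter of each other, so adding the aromatic ring alone does not account for the separation. No evidence at hand bears on why hydroxy and nitro differ here.

The compounds shown leave open whether the lower number depends on hydroxy itself or follows from the loss of nitro, which a methoxy group, an amine or a plain hydrogen in the same place would help to tell. They also leave open whether a hydroxy group elsewhere on this ring, or a second one, would give a number like that of compound 3.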